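The compounds below may be only part of what the source reports. "The series", "measured", "known", "first", "only" and "open" are said of these compounds alone.

Compound 3 `CCCc1nc(C)c2cnn(CC(O)CO)c(=O)n12` stands at the far edge of the numbers gathered so far. In a functional assay for inhibition, with Homo sapiens as the target (a higher number here means a weaker inhibitor, a lower number a stronger inhibitor), compound 3 gives > 48000 nM, which is a limit of the assay and not a number (the limit of > 48000 nM in this assay, at which 1 of the 3 values shown sits). Where compound 3 carries 1,2-dihydroxyethyl, compound 2 `CCCc1nc(C)c2cnn(C)c(=O)n12` carries hydrogen, and in this assay compound 2 gives 20000 nM. That change cost potency: an at least 2.4-fold higher number from compound 2 to compound 3 (0.38 log units; beyond the scatter). Compound 1 `C=CCn1nc(CCC)c2c(C)nc(CCC)n2c1=O` gives in this assay 29000 nM. Compound 4 `C=CCn1ncc2c(C)nc(CCC)n2c1=O` differs from compound 3 by vinyl in place of 1,2-dihydroxyethyl on a saturated chain carbon bound to an aromatic nitrogen. Within the data shown here, the only measured step that bears on this change is the one from compound 2 to compound 3, where the dihydroxyethyl group entered and the number rose at least modestly; compound 4 removes that group again, so the number is expected to move back down, by a modest amount and in the direction of a stronger inhibitor. Compound 4 is therefore estimated at 25000 nM, expected to lie between 10000 nM and 60000 nM. That estimate implies a step of an at least 1.9-fold lower number from compound 3 to compound 4 (0.28 log units; that floor lies within the scatter), expected to bring compound 4 back to the level of compound 1 and compound 2.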

Compound 4, half-maximal inhibitory concentration: 40000 nM
For compound 4 the middle estimate is 1.6-fold (0.20 log units) below the measured one; measured number inside the range.
By their numbers in this assay, from the lowest: compounds 2, 1 and 4 (each within the scatter of the next). At a limit, above all of these: compound 3.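

In this assay, vinyl in place of hydrogen on a saturated chain carbon bound to an aromatic nitrogen gives a 2.0-fold higher number from compound 2 to compound 4 (0.30 log units; within the scatter), and hydrogen in place of propyl on an aromatic carbon gives a 1.4-fold higher number from compound 1 to compound 4 (0.14 log units; within the scatter), so neither change separates compound 4 from compound 1 or compound 2. Vinyl in place of 1,2-dihydroxyethyl can be read only as an at least 1.2-fold lower number from compound 3 to compound 4 (0.07 log units; that floor lies within the scatter), which does not establish a real gain in potency. That step starts from a limit of the assay and not a number, held by compound 3: the limit of > 48000 nM in this assay, at which 1 of the 4 values shown sits.

The compounds shown leave open how far compound 3 truly lies from the others, and whether its hydroxyl groups or its chain length matter. Going by these compounds, whether an amine, a carboxylic acid or a longer chain at this place would give a clearly lower number also remains open.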